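Replacing methylamino with piperazin-1-yl on the shared core

This account rests on a few compounds, and the source may have more. Where it says the series, first, only, none or still open, it means among the compounds named here.

Compound 1 `CNc1nc(-c2cc(-c3ccon3)n(Cc3ccccc3F)n2)ncc1F` is the reference point. In an assay on a protein complex for activation of soluble guanylate cyclase (Homo sapiens), read by cGMP accumulation, in the presence of a further agent that is not named here (a higher number here means that more compound is needed for the effect, a lower number that less compound is needed), compound 1 gives 20 nM, the second highest of the three numbers measured. Compound 2 `OC1CCN(c2nc(-c3cc(-c4ccon4)n(Cc4ccccc4F)n3)ncc2F)CC1` gives 10 nM, and compound 3 `OCC1CCCCN1c1nc(-c2cc(-c3ccon3)n(Cc3ccccc3F)n2)ncc1F` gives 35 nM. The step of a 2.0-fold lower number from compound 1 to compound 2 (0.30 log units; within the scatter) and the step of a 1.8-fold higher number from compound 1 to compound 3 (0.24 log units; within the scatter) both stay within the scatter, while the step of a 3.5-fold higher number from compound 2 to compound 3 (0.54 log units; beyond the scatter) is modest but beyond it.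

Compound 4 `Fc1ccccc1Cn1nc(-c2ncc(F)c(N3CCNCC3)n2)cc1-c1ccon1` differs from compound 1 in one place: piperazin-1-yl in place of methylamino on an aromatic carbon. The two measured steps from compound 1 bear on this change, since each of them also exchanges methylamino for a six-membered non-aromatic ring on the same aromatic carbon, and neither moves the number beyond the scatter. Piperazin-1-yl itself has no measured precedent among these compounds. The step of a 1.1-fold lower number from compound 1 to compound 4 (0.05 log units; within the scatter) is therefore expected to stay within the scatter, in no particular direction. The estimate for compound 4 is 18 nM, with a range from 6 nM to 55 nM.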

Compound 4, half-maximal effective concentration: 120 nM
The estimate for compound 4 lay 6.7-fold (0.82 log units) below the measured number; measured number above the stated range.
By their numbers in this assay, from the lowest: compounds 2, 1 and 3 (each within the scatter of the next, the first and the last beyond it); then compound 4.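

In this assay, this position proves not to be indifferent to every six-membered non-aromatic ring: piperazin-1-yl gives a 6.0-fold higher number from compound 1 to compound 4 (0.78 log units; beyond the scatter), whereas the two hydroxy-bearing rings stayed within the scatter of methylamino. The identity of the ring therefore matters on this aromatic carbon, as the comparisons with those rings show: a 3.4-fold higher number from compound 3 to compound 4 (0.54 log units; beyond the scatter), and a 12-fold higher number from compound 2 to compound 4 (1.08 log units; beyond the scatter), the largest step in the set. No measurement shown here accounts for the rise in the number.

As far as these compounds go, it remains open whether the higher number goes with the second ring nitrogen or with the hydrogen it carries, a question that morpholin-4-yl or 4-methylpiperazin-1-yl on the same carbon would address. Also open, from the compounds shown here alone, is where unsubstituted piperidin-1-yl would fall relative to compound 2 and compound 4.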